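Cytotoxicity notes on a quinoxaline dioxide amine series

The compounds below may be only part of what the source reports. "The series", "measured", "known", "first", "only" and "open" are said of these compounds alone.

Measured compounds:
Compound 1 `[O-][n+]1nc(NC2CCC2)[n+]([O-])c2ccc(Cl)cc21` gives 1.6 ug/mL in an ADME assay on Vero cells (Chlorocebus sabaeus) for cytotoxicity, read by CellTiter-Glo, with a stated time of 72 h; on this read-out higher numbers stand for lower toxicity in this test and lower numbers for higher toxicity in this test.
Compound 2 `[O-][n+]1nc(N[C@@H]2C[C@H]3CC[C@@H]2C3)[n+]([O-])c2ccc(Cl)cc21` gives 1.1 ug/mL in this assay.
Compound 3 `COc1ccc2c(c1)[n+]([O-])nc(NC1CCC1)[n+]2[O-]` gives 9.8 ug/mL in this assay.

Compound 1 and compound 2 share the core of compound 1. Compound 2 carries a group of 7 heavy atoms (7 carbon; 2 five-membered non-aromatic rings of carbon only) in place of a group of 4 heavy atoms (4 carbon; one four-membered non-aromatic ring of carbon only), on a nitrogen on an aromatic ring, and the step in this assay is a 1.5-fold lower number from compound 1 to compound 2 (0.16 log units; within the scatter). Within the data shown here, compound 3 differs from compound 1 in the core by methoxy in place of chloro on an aromatic carbon; the step in this assay is a 6.1-fold higher number from compound 1 to compound 3 (0.79 log units; beyond the scatter), the only step among the three measured compounds that lies beyond the scatter, and compound 3 stands highest of the three.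

Compound 4 `COc1ccc2c(c1)[n+]([O-])nc(N[C@@H]1C[C@H]3CC[C@@H]1C3)[n+]2[O-]` is not yet measured. It differs from compound 3 by a group of 7 heavy atoms (7 carbon; 2 five-membered non-aromatic rings of carbon only) in place of a group of 4 heavy atoms (4 carbon; one four-membered non-aromatic ring of carbon only), on a nitrogen on an aromatic ring, which is the same change as that from compound 1 to compound 2, the place being the same word for word in both pairs. The change occurs twice among the compounds shown, once measured and once not.

Among the measured compounds shown here, for compound 4 the expected step in this assay is a 1.5-fold lower number from compound 3 to compound 4 (0.18 log units; within the scatter), put beside the measured 1.5-fold lower number from compound 1 to compound 2 (0.16 log units; within the scatter), because that step a 1.5-fold lower number from compound 1 to compound 2 (0.16 log units; within the scatter) was within the scatter on the core of compound 1, and nothing among the measured compounds indicates the change should act differently on the core of compound 3. Compound 4 is therefore estimated at 6.5 ug/mL in this assay. For the measured compounds named here, for compound 4 the expected range runs from 2.5 ug/mL to 17 ug/mL, the width reflecting that only one measured instance of this change exists.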

Compound 4, half-maximal cytotoxic concentration: > 50 ug/mL
Compound 4: only a limit was reported (the forecaster's own chance of this, stated with the estimate: 5%); middle value at least 7.6-fold (0.88 log units) from the limit.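

In this assay compound 4 is reported only as a limit, > 50 ug/mL. Cyclobutyl replaced by the group of 7 heavy atoms gives an at least 5.1-fold higher number from compound 3 to compound 4 (0.70 log units; beyond the scatter), so this change does not carry from the core of compound 1 to the core of compound 3 with the same size of step: the same change on two cores in this assay, a 1.5-fold lower number (0.16 log units; within the scatter) from compound 1 to compound 2 and an at least 5.1-fold higher number (0.70 log units; beyond the scatter) from compound 3 to compound 4, at least 7.4-fold (0.87 log units) apart, beyond the scatter of two such steps Methoxy in place of chloro gives an at least 45-fold higher number from compound 2 to compound 4 (1.65 log units; beyond the scatter), so that change also differs with the group on the nitrogen, and the four compounds show that the two changes do not act independently here, but not the true size of the departure, as the limit fixes only one side of it, nor any reason for it: the same change on two cores in this assay, a 6.1-fold higher number (0.79 log units; beyond the scatter) from compound 1 to compound 3 and an at least 45-fold higher number (1.65 log units; beyond the scatter) from compound 2 to compound 4, at least 7.4-fold (0.87 log units) apart, beyond the scatter of two such steps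

What remains open is whether the departure is specific to methoxy and to this group of 7 heavy atoms, or also appears with other pairs of groups. A fluoro or a methyl in place of methoxy on the aromatic carbon, and a cyclopentyl or a longer carbon chain on the nitrogen, would help separate these possibilities, and would show whether the size of the group on the nitrogen follows any trend on each core.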